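Solubility notes on two aryl-bearing analogues

The compounds below may be only part of what the source reports. "The series", "measured", "known", "first", "only" and "open" are said of these compounds alone.

Measured so far:
compound 1 `Cc1cc(NCc2ncc[nH]2)n2nc(C)c(-c3ccccc3)c2n1` — < 5000 nM
compound 2 `Cc1cc(NCc2ccccn2)n2ncc(-c3cc(F)c(F)c(F)c3)c2n1` — < 5000 nM

In a physicochemical assay for solubility, read by HPLC, using the shake flask method, measured as kinetic solubility, with a stated time of 2 h, at pH 7.4 (on this read-out lower numbers stand for lower solubility and higher numbers for higher solubility), compound 1 gives < 5000 nM, which is a limit of the assay rather than a number. Compound 2 gives < 5000 nM in this assay, again a limit and not a number. Nothing separates the two: both sit at the limit of < 5000 nM in this assay, at which 2 of the 2 values shown sit, so compound 2 stands no higher or lower than compound 1 on the numbers shown, and no measured step between compounds differing in one place is available.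

Compound 3 `Cc1cc(NCc2ccccn2)n2ncc(-c3ccc(F)cc3C)c2n1` is not yet measured in this assay. It differs from compound 2 by 4-fluoro-2-methylphenyl in place of 3,4,5-trifluorophenyl on an aromatic carbon. Going by the values given here, with no measured step to lean on, the change from compound 2 to compound 3 is expected to give no step in this assay beyond the scatter, so that a step that the limit leaves unreadable from compound 2 to compound 3 is the estimated shift. Compound 3 is expected to give about 3000 nM in this assay, between 500 nM and 10000 nM, with a fair chance of another limit.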

Compound 3, solubility: 42300 nM
Compound 3: middle estimate off by 14-fold (1.15 log units), on the low side, outside the stated range (above it).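

In this assay, going by these compounds alone, the aromatic carbon of the five-membered aromatic ring with 2 nitrogen is the first place where a single change gives a readable movement: 4-fluoro-2-methylphenyl in place of 3,4,5-trifluorophenyl gives an at least 8.4-fold higher number from compound 2 to compound 3 (0.92 log units; beyond the scatter). Compound 3 is also the only compound shown with a true number, 42300 nM. The aryl group at this position can therefore carry the read-out clear of the assay limit. The size of the step is only a lower bound, since the reading of compound 2 is a limit: the limit of < 5000 nM in this assay, at which 2 of the 3 values shown sit.

This one pair cannot tell whether the step follows the added methyl or the fluorine atoms that leave. Going by these compounds, how a morpholine, an amine or a carboxylic acid on this aryl ring would read remains open.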